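The source may hold more compounds than are shown below. What is called first, only, known or untested is meant among the compounds shown, and "the series" means these compounds.

Of the compounds shown here, two of a shared core have been measured so far. Compound 1 `CC(=O)c1ccc(/C=C2\CCCN=C2c2cccnc2)cc1` carries an acetyl group on its aromatic ring, and in an assay on membranes from brain for displacement of a labelled ligand from Neuronal acetylcholine receptor; alpha4/beta2 (Rattus norvegicus), with a stated time of 3 h (a higher number here means a weaker inhibitor, a lower number a stronger inhibitor), compound 1 gives 4490 nM. Compound 2 `CC(C)(C)C(=O)Oc1ccccc1/C=C1\CCCN=C1c1cccnc1` is the other measured member, and in this assay compound 2 gives 1440 nM. Of the two numbers, compound 1 has the higher one, and the gap to compound 2 lies beyond the usual scatter of repeated measurements, so compound 1 is the weaker of the two in this pair.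

Compound 3 `N#Cc1ccc(/C=C2\CCCN=C2c2cccnc2)cc1` differs from compound 1 in one place: cyano in place of acetyl on an aromatic carbon. Among the compounds with values here, nothing among the measured compounds shows what this particular exchange does, as no pair of measured compounds differs only in this way. Both groups bring one hydrogen-bond acceptor and sit on the same aromatic carbon, so the change is expected to be modest, and the step in this assay is estimated to be small, leaning toward a slightly lower number, as a 1.5-fold lower number from compound 1 to compound 3 (0.18 log units; within the scatter). Compound 3 is therefore expected to give about 3000 nM, most likely between 1000 nM and 9000 nM.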

Compound 3, inhibition constant: 1230 nM
Compound 3: middle estimate off by 2.4-fold (0.39 log units), on the high side; the measured number falls inside the stated range.
By their numbers in this assay, from the lowest: compounds 3 and 2 (each within the scatter of the next); then compound 1.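

Within the data shown here, this is the first measured pair that differs in only one place: in this assay, cyano in place of acetyl on an aromatic carbon, para to a large group, gives a 3.7-fold lower number from compound 1 to compound 3 (0.56 log units; beyond the scatter). The result shows that this position is sensitive to which group it carries, even though the two groups have the same count of hydrogen-bond acceptors and no hydrogen-bond donors. No measurement here explains what lies behind this step.

Going by these compounds, it remains open how other groups would behave at this place, such as an amine, a carboxylic acid or a longer chain. A plain hydrogen on the same carbon would also help to show how much of the step comes from losing acetyl and how much from gaining cyano.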